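This account rests on a few compounds, and the source may have more. Where it says the series, first, only, none or still open, it means among the compounds named here.

Compound 1, `C#CCN(C)Cc1ccc(NC(=O)CCCC(=O)NO)cc1`: in a functional assay on PC-3 cells (Homo sapiens) for inhibition, read by MTT assay, with a stated time of 48 h (a lower number here means a stronger inhibitor of growth, a higher number a weaker inhibitor of growth), compound 1 gives > 10000 nM, which is a limit of the assay.
Compound 2, `C#CCN(C)Cc1ccc(NC(=O)CCCCC(=O)NO)cc1`: in this assay compound 2 gives > 10000 nM, again a limit.

Compound 2 thus stands only at a limit. For the measured compounds named here, the one measured step, a step that the two limits leave unreadable from compound 1 to compound 2, has no readable size, since both values sit at the same limit (the limit of > 10000 nM in this assay, at which 2 of the 2 values shown sit). Compound 3, `C#CCN(C)Cc1ccc(NC(=O)CCCCCC(=O)NO)cc1`, differs from compound 2 by (hydroxycarbamoyl)methyl in place of hydroxycarbamoyl on a saturated chain carbon, four bonds along the chain from a carbonyl carbon. That step bears on the change but gives no direction, so nothing beyond the scatter is expected. Compound 3 is expected to give 15000 nM, within 3000 nM to 60000 nM. The expected step is a step that the limit leaves unreadable from compound 2 to compound 3, most likely again a limit.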

Compound 3, concentration for 50% growth inhibition: > 10000 nM
Compound 3: a limit, no number; the forecaster's own chance of this, stated with the estimate: 75%; the middle value is on the limit's open side.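

For the compounds shown here, no step among compound 1, compound 2 and compound 3 can be read, as all their values are limits: the limit of > 10000 nM in this assay, at which 3 of the 3 values shown sit. In this assay the compounds shown leave open what actual growth-inhibiting concentration any of the three has.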